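The source may report more compounds than this note shows. Statements on the series, on what has been measured and on what is new or still open speak of the compounds shown alone.

Within the data shown here, only two compounds have been measured so far in a physicochemical assay for lipophilicity, in phosphate buffer, measured as octanol-water partition, at pH 11.5; a lower number here means a more polar compound, a higher number a more lipophilic compound. Compound 1 `CCCCCCCCNC(=N)NC(=N)Nc1ccc(C)cc1` gives 4.93, and compound 2 `CCCCCCNC(=N)NC(=N)Nc1ccc(C(F)(F)F)cc1` gives 4.31. Compound 2 is therefore the lower of the two, and its gap to compound 1 lies beyond the scatter.

Compound 3 `CCCCCCCCNC(=N)NC(=N)Nc1ccc(C(F)(F)F)cc1` departs from compound 2 by ethyl in place of hydrogen on a saturated chain carbon, six bonds along the chain from an amine nitrogen, with ethyl in place of hydrogen on a saturated chain carbon, six bonds along the chain from an amine nitrogen. Among the measured compounds shown here, no measured pair shows this change on its own, so any forecast in this assay remains uncertain. A rise beyond the scatter is expected. The longer chain of compound 3 also occurs in compound 1, which at 4.93 stands higher, although that pair also differs elsewhere. The estimated change is a number 0.89 log units higher from compound 2 to compound 3 (beyond the scatter). For compound 3 the expected value is 5.2, with an estimated range from 4.8 to 5.6.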

Compound 3, partition coefficient: 5.31
Beside the measured number, compound 3's estimate is 0.11 log units below it; the measured number falls inside the stated range.
By their numbers in this assay, from the lowest: compound 2; then compound 1; then compound 3.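

Compound 1 and compound 2 differ in two places at once, so neither change could be read alone; compound 3 now separates them. In this assay, ethyl in place of hydrogen on a saturated chain carbon, six bonds along the chain from an amine nitrogen, gives a number 1.00 log units higher from compound 2 to compound 3 (beyond the scatter), while trifluoromethyl in place of methyl on an aromatic carbon gives a number 0.38 log units higher from compound 1 to compound 3 (beyond the scatter), and both steps lie beyond the scatter. Nothing available explains either step.

Going by these compounds, each change is seen only once, on a single partner, so it remains open whether the ethyl step would be the same with methyl on the aromatic carbon. Also open, on these data alone, are how a longer chain at the same place, or chlorine or methoxy in place of trifluoromethyl, would read.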